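The source may report more compounds than this note shows. Statements on the series, on what has been measured and on what is new or still open speak of the compounds shown alone.

Measured compounds. Compound 1 `O=C(Nc1cc(Sc2ncn[nH]2)c(O)c2ccccc12)c1ccc2ccccc2c1` gives in a functional assay on PC-3 cells (Homo sapiens) for antiproliferative activity, read by MTT assay, with a stated time of 48 h; a higher number here means a weaker inhibitor, a lower number a stronger inhibitor > 100000 nM, which is a limit of the assay and not a number. Compound 2 `O=C(Nc1cc(Sc2ncnc3nc[nH]c23)c(O)c2ccccc12)c1ccc(Cl)cc1` gives in this assay 66400 nM. Compound 3 `O=C(Nc1cc(Sc2ncnc3nc[nH]c23)c(O)c2ccccc12)c1ccc([N+](=O)[O-])cc1` gives in this assay > 100000 nM, again a limit of the assay rather than a number.

Among the measured compounds shown here, compound 2 is therefore the only member of the set with a number in this assay; the other two sit at the limit of > 100000 nM in this assay, at which 2 of the 3 values shown sit. For the measured compounds named here, the one measured step, an at least 1.5-fold higher number from compound 2 to compound 3 (0.17 log units; that floor lies within the scatter), changes the amide aryl and is itself a step to a limit, so it says little about the part of the molecule that changes next.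

Compound 4 `Cn1nnnc1Sc1cc(NC(=O)c2ccc(Cl)cc2)c2ccccc2c1O` differs from compound 2 by a group of 6 heavy atoms (2 carbon, 4 nitrogen; one five-membered aromatic ring with 4 hetero atoms) in place of a group of 9 heavy atoms (5 carbon, 4 nitrogen; one five-membered aromatic ring with 2 hetero atoms, one six-membered aromatic ring with 2 hetero atoms), on a sulfur. Going by the values given here, no measured step touches this sulfur substituent; compound 1 carries a different group on the sulfur but also a different acyl part, so its two values with compound 2 cannot be read as one step. With nothing to lean on, the expectation for this assay is no change beyond the scatter, or at most a small rise, and the step from compound 2 to compound 4 is estimated at a 1.4-fold higher number from compound 2 to compound 4 (0.13 log units; within the scatter). Compound 4 is expected to give about 90000 nM, within 35000 nM to 250000 nM.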

Compound 4, half-maximal inhibitory concentration: > 100000 nM
Compound 4: only a limit was reported (the forecaster's own chance of this, stated with the estimate: 45%); middle value at least 1.1-fold (0.04 log units) away from the limit.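

Among the compounds shown here, with the rest of the molecule held the same, the first readable change at this sulfur, to 1-methyl-1H-tetrazol-5-yl, is an at least 1.5-fold higher number from compound 2 to compound 4 (0.17 log units; that floor lies within the scatter) in this assay. This step ends at a limit of the assay and not at a number, so it gives only a floor, and the true size of the change could be anywhere from within the scatter to well beyond it. No gain appears with this group, since compound 4 joins compounds 1 and 3 at one shared limit and compound 2 remains the only member of the set with a number: the limit of > 100000 nM in this assay, at which 3 of the 4 values shown sit.

The compounds shown leave open how compounds 1, 3 and 4 rank against each other, as none of the three has a number. They also leave open whether a group on this sulfur that carries no ring at all, such as a methyl or a short chain ending in a carboxylic acid or an amine, would give a clearly lower number than compound 2 at 66400 nM.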